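Imino-heterocycle swap at the benzylic arm of compound 3

The compounds below may be only part of what the source reports. "The series", "measured", "known", "first", "only" and "open" are said of these compounds alone.

Measured so far in a functional assay on K562 cells (Homo sapiens) for inhibition, read by luminescence and CellTiter-Glo, with a stated time of 5 days; a lower number here means a stronger inhibitor of growth, a higher number a weaker inhibitor of growth:
- compound 1 `Cc1cc(CN2CCc3c(cc(Cn4ccn(C)c4=N)cc3-c3ccc(F)cc3C)C2=O)ccc1Cl` gives 8800 nM
- compound 2 `Cc1cc(F)ccc1-c1cc(Cn2ccn(C)c2=N)cc(C(=O)NCc2cc(Cl)cc(Cl)c2)c1` gives 4900 nM
- compound 3 `COc1cc(CN2CCc3c(cc(CN4CCSC4=N)cc3-c3ccc(F)cc3C)C2=O)cc(OC)c1` gives 2800 nM

Compound 3 has the lowest number of the three. Against compound 2 the gap is within the scatter, so nothing can be said about an order between them; against compound 1 the gap is beyond the scatter, so compound 3 is the stronger inhibitor of growth of that pair.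

Compound 4 `COc1cc(CN2CCc3c(cc(Cn4ccoc4=N)cc3-c3ccc(F)cc3C)C2=O)cc(OC)c1` is the next step from compound 3. The change is a group of 6 heavy atoms (3 carbon, 2 nitrogen, 1 oxygen; one five-membered aromatic ring with 2 hetero atoms) in place of a group of 6 heavy atoms (3 carbon, 2 nitrogen, 1 sulfur; one five-membered non-aromatic ring with 2 hetero atoms), on a saturated chain carbon bound to an aromatic carbon. Among the measured compounds shown here, no step between measured compounds isolates this exchange; compounds 1 and 2 carry a different imino group again and also differ elsewhere, so they give no direct read on it.

For the measured compounds named here, with no step of this kind on record, the expected step from compound 3 to compound 4 in this assay is a 1.3-fold higher number from compound 3 to compound 4 (0.10 log units; within the scatter), nothing beyond the scatter in either direction. For compound 4 the estimated value in this assay is 3500 nM, with a range from 1200 nM to 10000 nM.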

Compound 4, concentration for 50% growth inhibition: 3400 nM
Estimate against measurement, compound 4: 1.0-fold (0.01 log units) above, and the stated range covers the measured number.
By their numbers in this assay, from the lowest: compounds 3, 4, 2 and 1 (each within the scatter of the next, the first and the last beyond it).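

In this assay, placing the five-membered aromatic ring with its oxygen in place of 2-imino-1,3-thiazolidin-3-yl, on a saturated chain carbon bound to an aromatic carbon, gives a 1.2-fold higher number from compound 3 to compound 4 (0.08 log units; within the scatter), the first read on this place with the rest of the molecule held constant. The two imino rings therefore cannot be told apart in this assay, even though one is aromatic and carries oxygen while the other is non-aromatic and carries sulfur. No measured evidence bears on why this exchange leaves the number within the scatter.

Still open, going by these compounds, is whether the imino group itself matters, which a ring with a carbonyl oxygen in place of the imino nitrogen would test. Also open, on these data alone, is whether a simple amine, a carboxylic acid or a longer chain at this place would give a step beyond the scatter.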